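A few compounds are considered here, and "the series" means these few. Any claim that something is new, unique, unknown or untested is made for them only; others in the source may bear on it.

Measured compounds in a functional assay on NUGC-3 cells (Homo sapiens) for inhibition, read by sulforhodamine B assay, with a stated time of 48 h; on this read-out higher numbers stand for weaker inhibition of growth and lower numbers for stronger inhibition of growth:
Compound 1 `O=C(Nc1ccccc1O)C1c2ccccc2CCN1C(=O)c1ccc(Cl)cc1` gives > 10000 nM, a limit of the assay.
Compound 2 `O=C(Nc1ccccc1O)C1NCCc2ccccc21` gives > 10000 nM, also a limit.
Compound 3 `O=C(Nc1ccccc1O)c1nccc2ccccc12` gives > 10000 nM, again a limit.

Compound 1 therefore stands at the limit shared by all three, (the limit of > 10000 nM in this assay, at which 3 of the 3 values shown sit). Among the measured compounds shown here, the one measured step that changes a single place, a step that the two limits leave unreadable from compound 1 to compound 2, runs between two limits and cannot be read. Compound 4 `O=C(Nc1cccc(C(F)(F)F)c1)C1c2ccccc2CCN1C(=O)c1ccc(Cl)cc1` differs from compound 1 by 3-(trifluoromethyl)phenyl in place of 2-hydroxyphenyl on an amide-type nitrogen. For the measured compounds named here, no measured step touches that amide-type nitrogen, so nothing shows how large a change in this assay to expect, or in which direction. The expectation for compound 4 therefore rests on where compound 1 stands: an estimated 15000 nM, within 3000 nM to 60000 nM, meaning an expected step that the limit leaves unreadable from compound 1 to compound 4 from compound 1.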

Compound 4, concentration for 50% growth inhibition: > 10000 nM
Compound 4: a limit, no number (the forecaster's own chance of this, stated with the estimate: 70%); the middle value lies beyond the limit too.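

Compound 1 and compound 4 both give a limit rather than a number, so the step between them cannot be read. The compounds shown leave open which change, if any, would give a measurable value in this assay.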